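From Compound 1 to Compound 3: A Shorter Carboxy Group

A few compounds are considered here, and "the series" means these few. Any claim that something is new, unique, unknown or untested is made for them only; others in the source may bear on it.

Measured in an ADME assay on the whole organism (plasma, Rattus norvegicus) for protein binding, using cassette dosing, at a dose of 1 mg/kg; on this read-out lower numbers stand for a smaller free fraction and higher numbers for a larger free fraction:
compound 1 `Cc1ccc(Cn2c(=O)n(CC(C)(C)C(=O)O)c(=O)[nH]/c2=N\c2ccc(OC(C)C)c(Cl)c2)cc1`: 0.01
compound 2 `CC(C)Oc1ccc(/N=c2\[nH]c(=O)n(C[C@@H](O)CO)c(=O)n2Cc2ccc(Cl)cc2)cc1Cl`: 0.001

Compound 1 at 0.01 holds the higher of the two numbers, and compound 2 at 0.001 lies lower, a gap beyond the usual scatter. Compound 3 `Cc1ccc(Cn2c(=O)n(C[C@H](C)C(=O)O)c(=O)[nH]/c2=N\c2ccc(OC(C)C)c(Cl)c2)cc1` has not yet been measured in this assay. It carries 1-carboxyethyl in place of 1-carboxy-1-methylethyl on a saturated chain carbon bound to an aromatic nitrogen. Going by the values given here, no measured pair shows this change, so no shift beyond the scatter is expected. The expected step of a 1.2-fold higher number from compound 1 to compound 3 (0.08 log units; within the scatter) remains within the scatter. For compound 3 the estimate is 0.012, with an expected range from 0.005 to 0.03.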

Compound 3, unbound fraction: 0.014
For compound 3 the middle estimate is 1.2-fold (0.07 log units) below the measured one, and the stated range covers the measured number.
By their numbers in this assay, from the lowest: compound 2; then compounds 1 and 3 (each within the scatter of the next).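

In this assay, putting 1-carboxyethyl in place of 1-carboxy-1-methylethyl on a saturated chain carbon bound to an aromatic nitrogen gives (a 1.4-fold higher number from compound 1 to compound 3 (0.15 log units; within the scatter)). This single pair therefore shows that, at this position, the read-out does not separate the two groups. No measurement at hand accounts for this result. The compounds shown leave open whether the mirror-image form of 1-carboxyethyl, a longer chain ending in a carboxylic acid, or an amine at this place would shift the unbound fraction beyond the scatter.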